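Aryl swap on the carbonyl carbon of the series

The source may report more compounds than this note shows. Statements on the series, on what has been measured and on what is new or still open speak of the compounds shown alone.

Compound 2 `COc1cc(-c2cc(/C=C/C(=O)c3ccc(Cl)c(Cl)c3)[nH]n2)cc(OC)c1OC` is one of two members measured in a functional assay on Malme-3M cells (Homo sapiens) for cytotoxicity, read by sulforhodamine B assay, with a stated time of 48 h, tested at 0.1 uM; a higher number here means a weaker effect of the compound at the concentration tested, a lower number a stronger effect. Compound 2 gives 95%, while compound 1 `COc1cc(-c2cc(/C=C/C(=O)c3ccc(N)cc3)[nH]n2)cc(OC)c1OC` gives 102%. For the measured compounds named here, the only measured step, a number 7 percentage points lower from compound 1 to compound 2 (within the scatter), does not separate the two. Compound 3 `COc1ccc(C(=O)/C=C/c2cc(-c3cc(OC)c(OC)c(OC)c3)n[nH]2)cc1OC` is unmeasured; it differs from compound 2 by 3,4-dimethoxyphenyl in place of 3,4-dichlorophenyl on a carbonyl carbon. Going by the values given here, the one step already measured on a carbonyl carbon, a number 7 percentage points lower from compound 1 to compound 2 (within the scatter), stayed within the scatter, so compound 3 is expected to move by a number 1 percentage points higher from compound 2 to compound 3 (within the scatter), which is no step beyond the scatter. Compound 3 is estimated at 96%, with a range from 82% to 110%.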

Compound 3, a percentage reported as activity, at one concentration (the size of the read-out at that concentration, not a potency): 92%
Beside the measured number, compound 3's estimate is 4 percentage points above it, within the range that was stated.
By their numbers in this assay, from the lowest: compounds 3, 2 and 1 (each within the scatter of the next).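

At the carbonyl carbon, 3,4-dimethoxyphenyl in place of 3,4-dichlorophenyl stays within the scatter in this assay (a number 3 percentage points lower from compound 2 to compound 3 (within the scatter)), and the comparison with the 4-aminophenyl member also stays within it (a number 10 percentage points lower from compound 1 to compound 3 (within the scatter)). The entering group brings hydrogen-bond acceptors that 3,4-dichlorophenyl lacks, yet the readings do not separate. Three different aryl groups at this position now give no distinguishable reading at the tested concentration.

From the compounds shown here alone, whether a carboxylic acid or a pyridine ring on this carbon would move the reading beyond the scatter stays open. No available evidence bears on these readings.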